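Cytotoxicity notes on a trimethoxyphenyl series

A few compounds are considered here, and "the series" means these few. Any claim that something is new, unique, unknown or untested is made for them only; others in the source may bear on it.

Measured compounds:
Compound 1, `COc1ccc(-c2cc(-c3cc(OC)c(OC)c(OC)c3)nc(N)n2)cc1`, in an ADME assay on THP-1 cells (Homo sapiens) for cytotoxicity, read by MTT assay (a lower number here means that less compound is tolerated, a higher number that more compound is tolerated), gives 100000 nM.
Compound 2, `COc1cc(C2CC(c3ccc(Br)cc3)=NN2C(C)=O)cc(OC)c1OC`, in this assay gives 100000 nM.
Compound 3, `COc1cc(C2CC(c3ccc(Cl)cc3)=NN2C(C)=O)cc(OC)c1OC`, in this assay gives 100000 nM.

Compound 3 stands level with compounds 1 and 2 at the digits shown; nothing separates the three in this assay, and the only single-point step among them, no change at the digits printed from compound 2 to compound 3 (within the scatter), shows no change within the scatter. Compound 3 shares its core and the acetyl group with compound 2 and differs from it only at the halogen.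

Compound 4, `COc1ccc(C2=NN(C(C)=O)C(c3cc(OC)c(OC)c(OC)c3)C2)cc1`, has not yet been measured in this assay. It differs from compound 3 by methoxy in place of chloro on an aromatic carbon. For the measured compounds named here, the one step that bears on this is no change at the digits printed from compound 2 to compound 3 (within the scatter): a halogen exchange at the same aromatic carbon left the value unchanged, and compound 1, with a different core, sits at the same value. Going by the values given here, no step in this set has moved the read-out, so no direction can be argued for, and a step of no change beyond the scatter is expected for compound 4, no change at the digits printed from compound 3 to compound 4 (within the scatter).

For compound 4 the expected value in this assay is therefore 100000 nM, with a range from 50000 nM to 100000 nM.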

Compound 4, half-maximal cytotoxic concentration: 200000 nM
Beside the measured number, compound 4's estimate is 2.0-fold (0.30 log units) below it; measured number above the stated range.
By their numbers in this assay, from the lowest: compounds 1, 2, 3 and 4 (each within the scatter of the next).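

In this assay the position on the aromatic carbon para to a large group now carries something other than a halogen: 4-chlorophenyl to 4-methoxyphenyl gives a 2.0-fold higher number from compound 3 to compound 4 (0.30 log units; within the scatter) on the shared core, and methoxy in place of bromo gives a 2.0-fold higher number from compound 2 to compound 4 (0.30 log units; within the scatter) at the same place. The earlier step covered only an exchange of one halogen for another, whereas these two steps bring in a group with an oxygen, a hydrogen-bond acceptor and one more heavy atom, and both still lie within the scatter, so neither gives a direction for this position. Nothing shown gives a reason for the size of either step, and no supporting measurement bears on this result.

On these data alone, whether an amine or a carboxylic acid on the same aromatic carbon, or a longer chain such as ethoxy or butoxy there, would give a step beyond the scatter remains open. Also open, as far as these compounds go, is whether a longer chain in place of the acetyl group, or a change to the trimethoxyphenyl group, would move the read-out at all.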